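Replacing the hydroxy-methoxyphenyl arm of compound 2 with a dihalophenyl

The compounds below may be only part of what the source reports. "The series", "measured", "known", "first", "only" and "open" are said of these compounds alone.

Compound 2 `COc1ccc(/C=N/NC(=S)N/N=C2\C(=O)Nc3ccc(C)cc32)cc1O` gives 3190 nM in a functional assay on COS-7 cells (Chlorocebus aethiops) for inhibition, read by MTT assay; a higher number here means a weaker inhibitor, a lower number a stronger inhibitor. Compound 3 `COc1ccc(/C=N/NC(=S)N/N=C2\C(=O)Nc3ccc(Br)cc32)cc1O` gives 3090 nM in this assay, and the step between them, a 1.0-fold lower number from compound 2 to compound 3 (0.01 log units; within the scatter), leaves the two numbers side by side. Among the measured numbers compound 2 therefore holds the higher of the two, with compound 3 nearest. Compound 1 `O=C1Nc2ccc(Br)cc2/C1=N/NC(=S)N/N=C/c1ccccc1Br` is recorded in this assay only as a limit, > 50000 nM. Going by the values given here, the one step that reaches a halogenated phenyl on the carbon with a double bond to nitrogen is an at least 16-fold lower number from compound 1 to compound 3 (1.20 log units; beyond the scatter), the large gain that followed when 3-hydroxy-4-methoxyphenyl took the place of 2-bromophenyl.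

Compound 4 `Cc1ccc2c(c1)/C(=N/NC(=S)N/N=C/c1c(F)cccc1Cl)C(=O)N2` has not yet been measured. It differs from compound 2 by 2-chloro-6-fluorophenyl in place of 3-hydroxy-4-methoxyphenyl on a carbon with a double bond to nitrogen. This change runs in the opposite direction to the measured step, so a large rise in this assay is expected, quite possibly beyond what the assay can report as a number. Compound 4 is estimated at 50000 nM, within 10000 nM to 200000 nM, a step of a 16-fold higher number from compound 2 to compound 4 (1.20 log units; beyond the scatter).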

Compound 4, half-maximal inhibitory concentration: 2190 nM
Compound 4: middle estimate off by 23-fold (1.36 log units), on the high side; measured number below the stated range.
By their numbers in this assay, from the lowest: compounds 4, 3 and 2 (each within the scatter of the next). At a limit, above all of these: compound 1.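

Setting 2-chloro-6-fluorophenyl in place of 3-hydroxy-4-methoxyphenyl on the carbon with a double bond to nitrogen gives, in this assay, a 1.5-fold lower number from compound 2 to compound 4 (0.16 log units; within the scatter). In this pair, the arm can therefore lose its hydroxy and methoxy groups, with the hydrogen-bond donor and acceptors counted there, and the number stays within the scatter. A halogenated phenyl on this carbon thus does not by itself go with a limit, and compound 1, with its 2-bromophenyl, stands as the case against any such reading, its value being only a limit: the limit of > 50000 nM in this assay, at which 1 of the 4 values shown sits.

On these data alone, it remains open whether 2-bromophenyl on the core of compound 2 would reach that limit too, as compound 1 differs from compound 4 in more than one place. As far as these compounds go, how an amine or a carboxylic acid on this phenyl ring would read in this assay also remains open.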